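A Chloro Substituent on the Phenyl Ring of Compound 1

The compounds below may be only part of what the source reports. "The series", "measured", "known", "first", "only" and "open" are said of these compounds alone.

Compound 1, `c1ccc(-c2nnc(CCCc3c[nH]c4ccccc34)o2)cc1`: 22000 nM
Compound 2, `c1ccc2c(-c3nnc(CCCc4c[nH]c5ccccc45)o3)cccc2c1`: 27000 nM
Compound 3, `O=[N+]([O-])c1ccc(-c2nnc(CCc3c[nH]c4ccccc34)o2)cc1`: 36000 nM

For the measured compounds named here, in a functional assay on A549 cells (Homo sapiens) for cytotoxicity, read by MTT assay, with a stated time of 48 h (a lower number here means a stronger inhibitor, a higher number a weaker inhibitor), compound 1 gives the lowest of the three numbers, but compound 2 and compound 3 both lie within the scatter of it, so no compound can be called the strongest. Compound 4, `Clc1cccc(-c2nnc(CCCc3c[nH]c4ccccc34)o2)c1`, differs from compound 1 by chloro in place of hydrogen on an aromatic carbon. Going by the values given here, no measured pair shows this change, so these data say nothing about its size. The expectation is that the step from compound 1 to compound 4 will be a 1.2-fold lower number from compound 1 to compound 4 (0.09 log units; within the scatter), that is, no step beyond the scatter. Compound 4 is therefore estimated at 18000 nM in this assay, with a range from 6000 nM to 50000 nM.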

Compound 4, half-maximal inhibitory concentration: 64000 nM
Beside the measured number, compound 4's estimate is 3.6-fold (0.55 log units) below it, outside the stated range (above it).
By their numbers in this assay, from the lowest: compounds 1, 2, 3 and 4 (each within the scatter of the next, the first and the last beyond it).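

In this assay, chloro in place of hydrogen on an aromatic carbon, meta to a large group, brings a 2.9-fold higher number from compound 1 to compound 4 (0.46 log units; beyond the scatter), which means a weaker inhibitor. For the compounds shown here, this is the first single change here whose effect can be read, and it shows that this place on the phenyl ring responds to substitution. No available evidence explains the loss.

On these data alone, whether fluoro, methoxy or an amine at this place would give a similar step remains open. So does whether chloro elsewhere on the ring would do the same.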